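The compounds below may be only part of what the source reports. "The series", "measured", "known", "first", "only" and "open" are said of these compounds alone.

Measured so far:
Compound 1 `CN(c1ccc(NC(=O)c2ccc(C(F)(F)F)cc2C(F)(F)F)cc1OCc1cccc(C(F)(F)F)c1)S(=O)(=O)Cc1ccccc1` gives 176000 nM
Compound 2 `CN(c1ccc(NC(=O)c2cc(C(F)(F)F)cc(C(F)(F)F)c2)cc1OCc1ccc(C(F)(F)F)cc1)S(=O)(=O)Cc1ccccc1` gives 293000 nM

In an ADME assay on HEK293 cells (Homo sapiens) for cytotoxicity, read by MTT assay, with a stated time of 48 h (on this read-out lower numbers stand for stronger inhibition and higher numbers for weaker inhibition), compound 2 (293000 nM) stands within the scatter of compound 1 (176000 nM), so the two numbers cannot be told apart. For the measured compounds named here, both compounds sit in the same region of the scale, and no measured pair differs in one place only.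

Compound 3 `CCCCCCOc1cc(NC(=O)c2cc(C(F)(F)F)cc(C(F)(F)F)c2)ccc1N(C)S(=O)(=O)Cc1ccccc1` keeps the rest of compound 2 but carries pentyl in place of 4-(trifluoromethyl)phenyl on a saturated chain carbon bound to an oxygen on an aromatic ring. Cut one bond further out, the same difference reads (4-(trifluoromethyl)benzyl)oxy to hexyloxy.

The data hold no direct measure of this exchange, so the expectation rests only on the level set by compound 2 (293000 nM). No step beyond the scatter is expected, at most a small move towards lower numbers, an estimated 1.5-fold lower number from compound 2 to compound 3 (0.19 log units; within the scatter) in all. For compound 3 the estimated value in this assay is 190000 nM with an expected range from 70000 nM to 450000 nM on this read-out.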

Compound 3, half-maximal inhibitory concentration: 69900 nM
For compound 3 the middle estimate is 2.7-fold (0.43 log units) above the measured one; measured number outside the range, below it.
By their numbers in this assay, from the lowest: compound 3; then compounds 1 and 2 (each within the scatter of the next).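

In this assay, for the compounds shown here, putting pentyl in place of 4-(trifluoromethyl)phenyl on a saturated chain carbon bound to an oxygen on an aromatic ring gives a 4.2-fold lower number from compound 2 to compound 3 (0.62 log units; beyond the scatter), and this is the first step that can be read between two compounds differing in one place only. It shows that this place is not silent on this read-out: the shared core with the (4-(trifluoromethyl)benzyl)oxy group replaced by hexyloxy moves towards stronger inhibition, so neither the aromatic ring of the leaving group nor its fluorine atoms are needed for the lower number. Nothing at hand explains why the number moves in this direction.

This single step removes the ring and the fluorine atoms and changes the size of the group all at once, so the compounds shown cannot say which of these differences carries the shift. Also open, as far as these compounds go, is whether a longer chain, an unsubstituted benzyl group or a chain ending in an amine at this place would give a number nearer to that of compound 3 or further from it.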